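A few compounds are considered here, and "the series" means these few. Any claim that something is new, unique, unknown or untested is made for them only; others in the source may bear on it.

Compound 1, `O=C(/C=C/c1cn(-c2ccccc2)nc1-c1ccsc1)c1ccccc1`, gives 5100 nM in a functional assay on HCT-116 cells (Homo sapiens) for inhibition, read by sulforhodamine B assay, with a stated time of 72 h; on this read-out higher numbers stand for weaker inhibition and lower numbers for stronger inhibition.
Compound 2, `COc1ccc(OC)c(C(=O)/C=C/c2cn(-c3ccccc3)nc2-c2ccsc2)c1`, gives 3400 nM in this assay.
Compound 3, `O=C(/C=C/c1cn(-c2ccccc2)nc1-c1cccnc1)c1ccccc1`, gives 2000 nM in this assay.

Among the compounds with values here, compound 3 carries the lowest of the three numbers, but its gap to compound 2 lies within the scatter, so those two cannot be ranked against each other; only the step of a 2.6-fold lower number from compound 1 to compound 3 (0.41 log units; beyond the scatter) reaches beyond the scatter, and it is modest. Compound 4, `COc1ccc(C(=O)/C=C/c2cn(-c3ccccc3)nc2-c2cccnc2)c(OC)c1`, keeps the pyridin-3-yl group of compound 3 and alters the other end of the molecule: 2,4-dimethoxyphenyl in place of phenyl on a carbonyl carbon. Within the data shown here, the closest precedent is the step of a 1.5-fold lower number from compound 1 to compound 2 (0.18 log units; within the scatter), where methoxy groups were also added to the phenyl on the carbonyl carbon, though in a different arrangement; that step stayed within the scatter. A single precedent with a differently arranged set of methoxy groups is thin ground, so the expectation is a small move at most, in either direction or none at all. Compound 4 is therefore expected to give about 1500 nM in this assay, with a likely range from 600 nM to 4000 nM, an expected step of a 1.3-fold lower number from compound 3 to compound 4 (0.12 log units; within the scatter).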

Compound 4, half-maximal inhibitory concentration: 1300 nM
For compound 4 the middle estimate is 1.2-fold (0.06 log units) above the measured one; measured number inside the range.
By their numbers in this assay, from the lowest: compounds 4, 3, 2 and 1 (each within the scatter of the next, the first and the last beyond it).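

With the pyridin-3-yl group in place, adding two methoxy groups to the phenyl on the carbonyl carbon gives a 1.5-fold lower number from compound 3 to compound 4 (0.19 log units; within the scatter) in this assay. The thiophen-3-yl pair gave the same kind of result with a different methoxy arrangement, a 1.5-fold lower number from compound 1 to compound 2 (0.18 log units; within the scatter), so neither listed change at this position moves the number beyond the scatter, and neither methoxy arrangement costs measurable activity in these pairs. No measurement at hand explains why this position responds so little.

The compounds shown leave open whether a single methoxy group would behave the same way, and whether an amine or a carboxylic acid on this phenyl would shift the number beyond the scatter. They also leave open how far this tolerance extends to larger groups at this position.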